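This account rests on a few compounds, and the source may have more. Where it says the series, first, only, none or still open, it means among the compounds named here.

Three compounds have been measured in a functional assay on MCF7 cells (Homo sapiens) for inhibition, read by MTT assay, with a stated time of 48 h; on this read-out higher numbers stand for weaker inhibition of growth and lower numbers for stronger inhibition of growth:

Compound 1 `CN1CC[C@H](c2c(O)cc(O)c3c(=O)cc(/C=C/c4ccccc4)oc23)[C@H](O)C1`: 31000 nM
Compound 2 `CN1CC[C@H](c2c(O)cc(O)c3c(=O)cc(/C=C/c4ccc(Cl)cc4)oc23)[C@H](O)C1`: 49000 nM
Compound 3 `CN1CC[C@H](c2c(O)cc(O)c3c(=O)cc(/C=C/c4cccc(F)c4)oc23)[C@H](O)C1`: 3000 nM

Compound 3 stands lowest of the three, and so shows the strongest inhibition of growth, with a gap beyond the scatter to each of the others. The next compound, compound 4 `CN1CC[C@H](c2c(O)cc(O)c3c(=O)cc(/C=C/c4ccccc4Cl)oc23)[C@H](O)C1`, has not yet been measured. It differs from compound 3 by 2-chlorophenyl in place of 3-fluorophenyl on a double-bonded chain carbon bound to a double-bonded chain carbon. In words, 2-chlorophenyl comes in place of 3-fluorophenyl on a double-bonded chain carbon bound to a double-bonded chain carbon.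

Going by the values given here, three measured steps bear on this change. Fluoro in place of hydrogen gave a 10-fold lower number from compound 1 to compound 3 (1.01 log units; beyond the scatter), a large step. Chloro in place of hydrogen gave only a 1.6-fold higher number from compound 1 to compound 2 (0.20 log units; within the scatter). The direct exchange of aryl groups gave a 16-fold lower number from compound 2 to compound 3 (1.21 log units; beyond the scatter), also large. Compound 4 gives up the fluoro group and carries a chloro group, so it is expected to move back towards compound 1 and compound 2. Among the compounds with values here, no measured compound carries the 2-chlorophenyl group, so the size of that move remains uncertain. The expected change in this assay is a 5.0-fold higher number from compound 3 to compound 4 (0.70 log units; beyond the scatter), a step beyond the scatter towards weaker inhibition. For compound 4 the estimated value is 15000 nM, with an expected range from 4000 nM to 50000 nM.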

Compound 4, concentration for 50% growth inhibition: 9000 nM
Compound 4: middle estimate off by 1.7-fold (0.22 log units), on the high side, within the range that was stated.
By their numbers in this assay, from the lowest: compound 3; then compound 4; then compounds 1 and 2 (each within the scatter of the next).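

In this assay the result shows that, at this place on a double-bonded chain carbon, it matters where the chloro group sits: 2-chlorophenyl brings a 3.4-fold lower number from compound 1 to compound 4 (0.54 log units; beyond the scatter) and also a 5.4-fold lower number from compound 2 to compound 4 (0.74 log units; beyond the scatter) while the earlier 4-chlorophenyl compound stayed within the scatter of the unsubstituted compound 1. Chloro in place of hydrogen can therefore lower the number here, so the earlier gain is no longer confined to the fluoro compound, although the exchange of 3-fluorophenyl for 2-chlorophenyl still gives a 3.0-fold higher number from compound 3 to compound 4 (0.48 log units; beyond the scatter) and leaves compound 3 the strongest inhibitor of growth among the four. Nothing shown here gives a measured reason for these differences.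

Compound 3 and compound 4 differ in both the halogen and its place, so the compounds shown cannot say which of the two accounts for the step between them. Open too, on these data alone, is how 3-chlorophenyl or 2-fluorophenyl would read at this place, and whether a group other than a halogen, such as methoxy or an amine on the same phenyl, would keep the lower numbers.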